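The compounds below may be only part of what the source reports. "The series", "measured", "known", "first", "only" and "open" are said of these compounds alone.

Of the compounds shown here, three sharing one core have been measured in a functional assay on HCT-116 cells (Homo sapiens) for inhibition, read by MTT assay, with a stated time of 48 h; a higher number here means a weaker inhibitor, a lower number a stronger inhibitor. In this assay compound 1 `COc1cc(-c2cc(-c3ccc(Br)cc3)nc(-c3ccccc3)n2)cc(OC)c1OC`, which carries a bromo group, gives 4320 nM. Compound 2 `COc1cc(-c2cc(-c3ccc(C)cc3)nc(-c3ccccc3)n2)cc(OC)c1OC`, with a methyl group in its place, gives 15700 nM, and compound 3 `COc1cc(-c2cc(-c3ccccc3)nc(-c3ccccc3)n2)cc(OC)c1OC`, with hydrogen there, gives 9950 nM. Compound 2 therefore lies in the upper part of this small range, level with compound 3 within the scatter: the data show a 1.6-fold lower number from compound 2 to compound 3 (0.20 log units; within the scatter). It stands clearly apart only from the bromo compound, with a 3.6-fold higher number from compound 1 to compound 2 (0.56 log units; beyond the scatter).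

The next compound, compound 4 `COc1ccc(-c2cc(-c3cc(OC)c(OC)c(OC)c3)nc(-c3ccccc3)n2)cc1`, has methoxy in place of methyl on an aromatic carbon, para to a large group: methoxy in place of methyl on an aromatic carbon. Among the compounds with values here, no measured compound carries methoxy at this place, so the evidence is indirect. Replacing methyl with hydrogen produced no step beyond the scatter, while the two steps away from bromo were modest, the second being a 2.3-fold higher number from compound 1 to compound 3 (0.36 log units; beyond the scatter). Only a small change is therefore expected in this assay, with no firm direction and perhaps a slight drop. The expected step is a 1.4-fold lower number from compound 2 to compound 4 (0.15 log units; within the scatter), which would stay within the scatter. For compound 4 the estimated value is 11000 nM, with an expected range of 5000 nM to 22000 nM.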

Compound 4, half-maximal inhibitory concentration: 4780 nM
Compound 4: middle estimate off by 2.3-fold (0.36 log units), on the high side; the measured number lies below the stated range.
By their numbers in this assay, from the lowest: compounds 1 and 4 (each within the scatter of the next); then compounds 3 and 2 (each within the scatter of the next).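

Para to a large group, this position proves able to respond to a substituent other than bromo: in this assay, the change from 4-methylphenyl to 4-methoxyphenyl gives a 3.3-fold lower number from compound 2 to compound 4 (0.52 log units; beyond the scatter), and methoxy also separates from hydrogen, with a 2.1-fold lower number from compound 3 to compound 4 (0.32 log units; beyond the scatter). Methoxy and bromo cannot be told apart, with a 1.1-fold higher number from compound 1 to compound 4 (0.04 log units; within the scatter), so two different groups reach the same level here, while methyl stays level with hydrogen. Nothing available accounts for this grouping of the four compounds.

The compounds shown leave open whether a hydroxyl group, an amine or a longer chain such as ethoxy at this same place would stay level with compound 4 or move away from it. They also leave open whether the methoxy step would carry over to the same change elsewhere on this aromatic ring, or to a cell line other than the one used in this assay.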